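Adding chloro to compound 2: working notes

This account rests on a few compounds, and the source may have more. Where it says the series, first, only, none or still open, it means among the compounds named here.

Measured so far in a functional assay on CCRF-CEM cells (Homo sapiens) for antiproliferative activity, with a stated time of 72 h; a higher number here means a weaker inhibitor, a lower number a stronger inhibitor
- compound 1 (`COc1ccc(-c2c(Cl)sc(=O)n2-c2cc(OC)c(OC)c(OC)c2)cc1[N+](=O)[O-]`) gives 7500 nM
- compound 2 (`COc1ccc(-c2csc(=O)n2-c2cc(OC)c(OC)c(OC)c2)cc1N`) gives 240 nM

Compound 2 has the lower number of the two, and the gap to compound 1 lies beyond the scatter. Compound 3 (`COc1ccc(-c2c(Cl)sc(=O)n2-c2cc(OC)c(OC)c(OC)c2)cc1N`) is compound 2 with chloro in place of hydrogen on an aromatic carbon, next to the ring sulfur and next to the ring atom that bears a 3-amino-4-methoxyphenyl group (chloro in place of hydrogen on an aromatic carbon). Among the measured compounds shown here, no two measured compounds differ in one place only, and the data give no direct size for this change. Compound 1 also carries chloro on that carbon, but its value alone does not isolate the change. In this assay a modest step is expected, just beyond the scatter. The change expected is a 2.4-fold lower number from compound 2 to compound 3 (0.38 log units; beyond the scatter) in the direction of a lower number, an estimate with wide uncertainty on either side. Compound 3 is estimated at 100 nM (expected range 15 nM to 600 nM).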

Compound 3, half-maximal inhibitory concentration: 120 nM
For compound 3 the middle estimate is 1.2-fold (0.08 log units) below the measured one; low and high end bracket the measured number.
By their numbers in this assay, from the lowest: compounds 3 and 2 (each within the scatter of the next); then compound 1.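

In this assay, among the compounds shown here, chloro in place of hydrogen on the aromatic carbon next to the ring sulfur gives a 2.0-fold lower number from compound 2 to compound 3 (0.30 log units; within the scatter) and so leaves compounds 2 and 3 indistinguishable: this position accepts chloro with no change that can be read beyond the scatter, which the earlier compounds could not show. With chloro present on both sides, amino in place of nitro on an aromatic carbon gives a 63-fold lower number from compound 1 to compound 3 (1.80 log units; beyond the scatter) in this assay as a large step, so the high number of compound 1 goes with its nitro group and not with its chloro. The data at hand offer no measurement that explains either step.

Still open, as far as these compounds go, is how much room this carbon offers beyond chloro, since only hydrogen and chloro appear there; a bromo, methyl or nitrile group at the same place would test whether the flat result extends to other substituents. On the phenyl ring, only amino and nitro are compared, so a hydroxyl or methylamino group in place of the amino would show how specific that large step is to the amino group.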